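The source may report more compounds than this note shows. Statements on the series, on what has been measured and on what is new or still open speak of the compounds shown alone.

Measured so far:
- compound 1, `Cc1ccc(Cn2cc(CNC(=O)c3cnc(Nc4ccc(C#N)cc4)cc3Oc3c(C)cc(C)cc3C)nn2)cc1`: 165000 nM
- compound 2, `Cc1cc(C)c(Oc2cc(Nc3ccc(C#N)cc3)ncc2C(=O)NCc2cn(Cc3ccccc3F)nn2)c(C)c1`: > 222000 nM
- compound 3, `CCOC(=O)Cn1cc(CNC(=O)c2cnc(Nc3ccc(C#N)cc3)cc2Oc2c(C)cc(C)cc2C)nn1`: 9530 nM

In an ADME assay on MT4 cells (Homo sapiens) for cytotoxicity, read by MTT assay, with a stated time of 5 days (a lower number here means that less compound is tolerated, a higher number that more compound is tolerated), compound 1 gives 165000 nM, the highest of the two numbers reported; its nearest neighbour is compound 3, which gives 9530 nM, a step of a 17-fold lower number from compound 1 to compound 3 (1.24 log units; beyond the scatter). For compound 2 only a limit is reported, > 222000 nM, so its step is an at least 1.3-fold higher number from compound 1 to compound 2 (0.12 log units; that floor lies within the scatter) and the limit of > 222000 nM in this assay, at which 1 of the 3 values shown sits, applies. Compound 4, `Cc1cc(C)c(Oc2cc(Nc3ccc(C#N)cc3)ncc2C(=O)NCc2cn(CCCO)nn2)c(C)c1`, is not yet measured in this assay. It differs from compound 1 by 2-hydroxyethyl in place of 4-methylphenyl on a saturated chain carbon bound to an aromatic nitrogen.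

The two measured steps that bear on this place tell different stories: swapping one aryl group for another, as in an at least 1.3-fold higher number from compound 1 to compound 2 (0.12 log units; that floor lies within the scatter), lies within the scatter, whereas replacing the aryl with a short non-aromatic chain, as in a 17-fold lower number from compound 1 to compound 3 (1.24 log units; beyond the scatter) and an at least 23-fold lower number from compound 2 to compound 3 (1.36 log units; beyond the scatter), gives a large drop. Compound 4 also carries a short chain rather than an aryl here, so a lower number than compound 1 is expected, though the chain differs from that of compound 3 and the size is uncertain. Compound 4 is therefore expected to give 60000 nM, between 15000 nM and 222000 nM, a step of a 2.8-fold lower number from compound 1 to compound 4 (0.44 log units; beyond the scatter).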

Compound 4, half-maximal cytotoxic concentration: 25200 nM
For compound 4 the middle estimate is 2.4-fold (0.38 log units) above the measured one; the measured number falls inside the stated range.
By their numbers in this assay, from the lowest: compound 3; then compound 4; then compound 1. At a limit, above all of these: compound 2.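

In this assay, the 2-hydroxyethyl group on a saturated chain carbon bound to an aromatic nitrogen also gives a lower number than the 4-methylphenyl group, with a 6.5-fold lower number from compound 1 to compound 4 (0.82 log units; beyond the scatter), so the drop is not confined to ethoxycarbonyl. The two non-aromatic groups are not interchangeable at this place either, with a 2.6-fold higher number from compound 3 to compound 4 (0.42 log units; beyond the scatter), which leaves compound 4 apart from compound 3 as well as from the compounds with an aryl group. Against the 2-fluorophenyl group the change is an at least 8.8-fold lower number from compound 2 to compound 4 (0.94 log units; beyond the scatter), and this is only a floor, as compound 2 is reported as a limit: the limit of > 222000 nM in this assay, at which 1 of the 4 values shown sits.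

As far as these compounds go, what stays open is whether the lower numbers go with the loss of the aromatic ring or with the smaller group, as compound 3 and compound 4 differ from compound 1 in both at once. Also open, from the compounds shown here alone, is where a plain alkyl chain, a longer chain ending in a hydroxyl, an amine or a carboxylic acid would fall at this place.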